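Chloro for Bromo in a Series Without Measurable Toxicity

This account rests on a few compounds, and the source may have more. Where it says the series, first, only, none or still open, it means among the compounds named here.

Compound 3 `Cn1c(-c2ccccc2)cnc1NC(=O)c1ccc(Br)cc1` was examined in a toxicity assay on THP-1 cells (Homo sapiens) for inhibition (on this read-out higher numbers stand for lower toxicity in this test and lower numbers for higher toxicity in this test), together with compound 1 `Cn1c(-c2ccccc2)cnc1NC(=O)c1ncc[nH]1` and compound 2 `COc1ccc(-c2cnc(NC(=O)c3ccc(Cl)cc3)n2C)cc1`. In this assay compound 1 reaches only the limit of the assay, > 100000 nM. In this assay compound 2 likewise gives only the limit, > 100000 nM. In this assay compound 3 also returns only the limit, > 100000 nM. Among the measured compounds shown here, compound 3 therefore stands at the same limit as the other two compounds, and the single measured step, a step that the two limits leave unreadable from compound 1 to compound 3, cannot be read because of the limit of > 100000 nM in this assay, at which 3 of the 3 values shown sit. Compound 4 `Cn1c(-c2ccccc2)cnc1NC(=O)c1ccc(Cl)cc1` differs from compound 3 by chloro in place of bromo on an aromatic carbon. For the measured compounds named here, no measured step involves one halogen replacing another, and the one step that exists is unreadable, so nothing here points to a change in this assay in either direction beyond the scatter. The estimate for compound 4 in this assay is accordingly 100000 nM, expected between 50000 nM and 300000 nM, which means an expected step of a number no higher from compound 3 to compound 4 (the limit leaves the size open) that amounts to nothing beyond the scatter.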

Compound 4, half-maximal cytotoxic concentration: > 100000 nM
Compound 4: a limit, no number; the forecaster's own chance of this, stated with the estimate: 85%; the middle value sits exactly at the limit.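

In this assay compound 4 gives > 100000 nM, which is a limit and not a number. The steps from compound 1, compound 2 and compound 3 to compound 4 therefore cannot be read: the limit of > 100000 nM in this assay, at which 4 of the 4 values shown sit.

The compounds shown leave open whether any of them differs from another in toxicity in this test.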